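Plasma Protein Binding: From Compound 1 to Compound 3

A few compounds are considered here, and "the series" means these few. Any claim that something is new, unique, unknown or untested is made for them only; others in the source may bear on it.

Measured compounds:
- compound 1 `Cc1cc(C(C)NC(=O)c2[nH]cc(Cc3ccc(C(F)(F)F)nc3)c2C)no1`: 93.7%
- compound 2 `Cc1cc(Nc2ccc(S(F)(F)(F)(F)F)cc2)n2nc(C(F)(F)F)nc2n1`: 97.5%

Of the compounds shown here, two have been measured in an ADME assay on a cell-free system (plasma, Rattus norvegicus) for protein binding. Compound 1 gives 93.7%, and compound 2 gives 97.5%. Of the two, compound 1 has the higher unbound fraction; compound 2 sits at a lower unbound fraction, and that gap lies beyond the usual scatter of this assay.

Compound 3 `Cc1c(Cc2ccc(C(F)(F)F)nc2)c[nH]c1C(=O)NC(C)c1cnn(C)c1` has not yet been measured. It differs from compound 1 in one place: 1-methyl-1H-pyrazol-4-yl in place of 5-methyl-1,2-oxazol-3-yl on a saturated chain carbon bound to an amide-type nitrogen and a saturated chain carbon. Among the compounds with values here, no pair of measured compounds shows this change, so there is no measured step to anchor it. The group that leaves and the group that enters match each other in what is counted, so the expected step in this assay is small, in no settled direction, and not beyond the scatter.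

Compound 3 is therefore expected to give 92%, with a range from 85% to 96%. This estimate means a step of a 1.3-fold higher unbound fraction from compound 1 to compound 3 (0.10 log units; within the scatter), which is expected to stay within the usual scatter.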

Compound 3, plasma protein binding in the Rattus norvegicus assay: 95.1%
Compound 3: middle estimate off by 1.6-fold (0.21 log units) (unbound fraction), on the high side, within the range that was stated.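

In the Rattus norvegicus assay, the first step measured at this position, on a saturated chain carbon bound to an amide-type nitrogen and a saturated chain carbon, puts 1-methyl-1H-pyrazol-4-yl in place of 5-methyl-1,2-oxazol-3-yl and gives a 1.3-fold lower unbound fraction from compound 1 to compound 3 (0.11 log units; within the scatter). In a physicochemical assay for solubility, in phosphate buffer, with a stated time of 5 h, at pH 7.4 (a higher number here means a more soluble compound, a lower number a less soluble compound), compound 1 gives 5.9 ug/mL, and compound 3 gives 49 ug/mL. The two rings match in what is counted, and the change leaves plasma protein binding within the scatter, yet in the physicochemical assay it separates the two compounds by more than the scatter: the measured solubility of compound 1, 5.9 ug/mL, and of compound 3, 49 ug/mL, an 8.3-fold higher number (0.92 log units; beyond the scatter)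

This change is seen in a single pair only, so it remains open whether the same exchange on another core would give a similar pair of steps, and compound 2 differs from both of these compounds in more than one place and offers no comparison. The compounds shown also leave open how a ring carrying a primary amine or a carboxylic acid at this same position would stand in the Rattus norvegicus assay and in the physicochemical assay.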